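The source may report more compounds than this note shows. Statements on the series, on what has been measured and on what is new or still open speak of the compounds shown alone.

Measured so far:
compound 1 `CCOC(=O)C1=Cc2ccccc2OC1(OCc1cn(-c2cccc(OC)c2)nn1)C(F)(F)F` — in a functional assay on HeLa cells (Homo sapiens) for inhibition, read by MTT assay, with a stated time of 24 h (a higher number here means a weaker inhibitor, a lower number a stronger inhibitor), compound 1 gives > 150000 nM, which is a limit of the assay.
compound 2 `CCOC(=O)C1=Cc2ccccc2OC1(OCc1cn(CC(=O)Nc2ccccc2Br)nn1)C(F)(F)F` — in this assay compound 2 gives > 150000 nM, again only a limit.

Compound 2 therefore stands at the limit, and so does every other value in the series, as stated by the limit of > 150000 nM in this assay, at which 2 of the 2 values shown sit. Going by the values given here, the single measured step, a step that the two limits leave unreadable from compound 1 to compound 2, cannot be read, since both of its ends are limits.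

Compound 3 `CCOC(=O)C1=Cc2ccccc2OC1(OCc1cn(-c2cccc(C(F)(F)F)c2)nn1)C(F)(F)F` differs from compound 2 by 3-(trifluoromethyl)phenyl in place of ((2-bromophenyl)carbamoyl)methyl on an aromatic nitrogen. Among the compounds with values here, no measured step bears on this change in a readable way; the step from compound 1 to compound 2 gives no size because both ends sit at the limit (the limit of > 150000 nM in this assay, at which 2 of the 2 values shown sit). No direction beyond the scatter can be derived. Compound 3 is therefore expected to remain at or near the limit, with an estimated value of 200000 nM in a range from 80000 nM to 500000 nM. This expectation corresponds to an estimated step that the limit leaves unreadable from compound 2 to compound 3.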

Compound 3, half-maximal inhibitory concentration: > 150000 nM
Compound 3: only a limit was reported; the forecaster's own chance of this, stated with the estimate: 85%; the middle value lies beyond the limit too.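

Going by these compounds alone, compound 3 adds no readable step: compound 1, compound 2 and compound 3 all sit at the limit of the assay, so no step among them can be read. The compounds shown leave open whether any group on the aromatic nitrogen brings a numerical value in this assay on the shared core, and which group would do so.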